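Benzyl ring substitution in the aryloxyethylamine series

The source may report more compounds than this note shows. Statements on the series, on what has been measured and on what is new or still open speak of the compounds shown alone.

Measured so far:
- compound 1 `COc1cccc(OC)c1OCCNCCOc1ccccc1OCc1ccccc1`: 9.37
- compound 2 `COc1cccc(OC)c1OCCNCCOc1ccccc1OCc1cccc(Cl)c1`: 8.72
- compound 3 `COc1cccc(OC)c1OCCNCCOc1ccccc1OCc1ccc(Cl)cc1`: 9.11

All three values come from a functional assay on thoracic aorta for antagonist activity at Alpha-1D adrenergic receptor (Rattus norvegicus); on this read-out lower numbers stand for lower potency and higher numbers for higher potency (the scale is a negative logarithm). Compound 3 stands second highest of the three; its value and that of compound 1 lie within the scatter of each other, so no order between them is claimed, while compound 2 lies below both. The measured steps: a number 0.65 log units lower from compound 1 to compound 2 (beyond the scatter), a number 0.26 log units lower from compound 1 to compound 3 (within the scatter) and a number 0.39 log units higher from compound 2 to compound 3 (beyond the scatter).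

Compound 4 `COc1cccc(OC)c1OCCNCCOc1ccccc1OCc1cccc(C)c1` has not been measured in this assay. The change from compound 3 is 3-methylphenyl in place of 4-chlorophenyl on a saturated chain carbon bound to an oxygen on an aromatic ring.

Two of the measured steps bear on it. Moving a chloro from the 4-position of the benzyl ring to the 3-position cost potency, as seen in a number 0.39 log units higher from compound 2 to compound 3 (beyond the scatter) read in reverse, and placing chloro at the 3-position in the first place gave a number 0.65 log units lower from compound 1 to compound 2 (beyond the scatter). Among the measured compounds shown here, compound 4 carries its group at the 3-position, but that group is methyl, for which no measured step exists. The expectation is therefore a modest drop rather than a large one, estimated as a number 0.26 log units lower from compound 3 to compound 4 (within the scatter). For compound 4 in this assay the estimate is 8.85, with a range from 8.4 to 9.3.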

Compound 4, negative logarithm of the antagonist equilibrium constant: 8.85
Compound 4: the middle estimate sits on the measured number at the digits printed, and the stated range covers the measured number.
By their numbers in this assay, from the lowest: compounds 2, 4, 3 and 1 (each within the scatter of the next, the first and the last beyond it).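

In this assay, the 3-position of the benzyl ring now has two different groups, and both sit beyond the scatter from the unsubstituted compound: a number 0.65 log units lower from compound 1 to compound 2 (beyond the scatter) for the chloro, and a number 0.52 log units lower from compound 1 to compound 4 (beyond the scatter) for the methyl. The two groups themselves are not separated, with a number 0.13 log units higher from compound 2 to compound 4 (within the scatter), so in this pair the read-out does not distinguish chloro from methyl at that position, and the lower level seen with compound 2 is no longer a single observation. Among the compounds shown here, the change from 4-chlorophenyl to 3-methylphenyl, a number 0.26 log units lower from compound 3 to compound 4 (within the scatter), also stays unresolved, so compound 3 cannot be separated from either compound 1 or compound 4, and the only step from the unsubstituted compound that stays within the scatter is the one to compound 3. No measurement at hand accounts for any of these differences.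

The compounds shown leave open whether methoxy or trifluoromethyl at the 3-position would fall at the same level as chloro and methyl. They also leave open whether 4-methylphenyl would stay within the scatter of compound 1, as 4-chlorophenyl does, which would show whether the position of the group matters for methyl as it does for chloro.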